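Benzimidazole-to-phenoxy swap on a pyrazole ester series

This account rests on a few compounds, and the source may have more. Where it says the series, first, only, none or still open, it means among the compounds named here.

Measured so far:
compound 1 `CCOC(=O)c1c(-c2ccccc2)nn(-c2ccccc2)c1Cn1c(Cl)nc2ccccc21` — 10 ug/mL
compound 2 `CCOC(=O)c1c(-c2ccccc2)nn(-c2ccccc2)c1Cn1c(S)nc2ccccc21` — 40 ug/mL

In an assay for inhibition of Alpha amylase (Homo sapiens), with a stated time of 30 min (on this read-out lower numbers stand for stronger inhibition and higher numbers for weaker inhibition), compound 2 gives 40 ug/mL, the higher of the two numbers in hand; compound 1 sits at 10 ug/mL. Among the compounds with values here, the only measured step, a 4.0-fold higher number from compound 1 to compound 2 (0.60 log units; beyond the scatter), was modest and concerned a single substituent on an aromatic carbon.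

Compound 3 `CCOC(=O)c1c(-c2ccccc2)nn(-c2ccccc2)c1COc1ccccc1C=O` is not yet measured. Its change from compound 2 is a group of 9 heavy atoms (7 carbon, 2 oxygen; one six-membered aromatic ring of carbon only) in place of a group of 10 heavy atoms (7 carbon, 2 nitrogen, 1 sulfur; one five-membered aromatic ring with 2 hetero atoms, one six-membered aromatic ring of carbon only), on a saturated chain carbon bound to an aromatic carbon. Within the data shown here, no measured step touches this part of the shared core, so the one step in hand bears on it only as a gauge of how much the numbers have moved so far. On that basis no large move is expected in this assay in either direction; the estimate for compound 3 is 25 ug/mL, with a range from 8 ug/mL to 80 ug/mL, a step of a 1.6-fold lower number from compound 2 to compound 3 (0.20 log units; within the scatter) that is expected to stay near the scatter.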

Compound 3, half-maximal inhibitory concentration: 40 ug/mL
Estimate against measurement, compound 3: 1.6-fold (0.20 log units) below; low and high end bracket the measured number.
By their numbers in this assay, from the lowest: compound 1; then compounds 2 and 3 (each within the scatter of the next).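

In this assay, within the data shown here, this is the first read on the whole group at the saturated chain carbon bound to an aromatic carbon, and it shows no change at the digits printed from compound 2 to compound 3 (within the scatter): 2-formylphenoxy, with its single six-membered aromatic ring and 0 hydrogen-bond donors, reads level with the sulfanyl-bearing group of compound 2. Measured against the chloro-bearing group, the same exchange gives a 4.0-fold higher number from compound 1 to compound 3 (0.60 log units; beyond the scatter), so compound 1 keeps the lowest number of the three. Nothing available explains either step.

As far as these compounds go, whether the formyl group matters at all remains open, and a plain phenoxy or a carboxylic acid in its place would address that. From the compounds shown here alone, it is also open whether a chloro group on the phenoxy ring would bring the number down toward that of compound 1.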